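Two Amide Variants of a Shared Core, One Swap Ahead

This account rests on a few compounds, and the source may have more. Where it says the series, first, only, none or still open, it means among the compounds named here.

Compound 1, `CC(C)c1c(C(=O)NCC2CCCCC2)nn(-c2ccc(F)cc2)c1OC[C@@H](O)C[C@@H](O)CC(=O)O`, in an assay on microsomes from liver for inhibition of 3-hydroxy-3-methylglutaryl-coenzyme A reductase (Rattus norvegicus); on this read-out lower numbers stand for stronger inhibition and higher numbers for weaker inhibition: 17 nM
Compound 2, `COc1ccc(CNC(=O)c2nn(-c3ccc(F)cc3)c(OC[C@@H](O)C[C@@H](O)CC(=O)O)c2C(C)C)cc1`, in this assay: 12 nM

For the measured compounds named here, compound 2 stands with the lowest of the two measured numbers, though its only neighbour is compound 1, and the move between them, a 1.4-fold lower number from compound 1 to compound 2 (0.15 log units; within the scatter), lies within the scatter. Going by the values given here, that one step is the only measured change at this position, and it shows that replacing cyclohexyl by 4-methoxyphenyl on a saturated chain carbon bound to an amide-type nitrogen left the read-out essentially unchanged.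

Compound 3, `CC(C)c1c(C(=O)NCc2cccc(Cl)c2)nn(-c2ccc(F)cc2)c1OC[C@@H](O)C[C@@H](O)CC(=O)O`, has not been measured yet. It differs from compound 2 in one place: 3-chlorophenyl in place of 4-methoxyphenyl on a saturated chain carbon bound to an amide-type nitrogen. Among the compounds with values here, no measured step covers this particular exchange, so the expectation rests only on the tolerance already seen at this position.

Compound 3 is therefore expected to give about 14 nM in this assay, between 5 nM and 40 nM, which corresponds to an expected step of a 1.2-fold higher number from compound 2 to compound 3 (0.07 log units; within the scatter), a change not beyond the scatter.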

Compound 3, half-maximal inhibitory concentration: 5.4 nM
For compound 3 the middle estimate is 2.6-fold (0.41 log units) above the measured one, within the range that was stated.
By their numbers in this assay, from the lowest: compound 3; then compounds 2 and 1 (each within the scatter of the next).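

In this assay, for the compounds shown here, the amide side chain turns out to be more than merely tolerant: 3-chlorophenyl in place of 4-methoxyphenyl gives a 2.2-fold lower number from compound 2 to compound 3 (0.35 log units; beyond the scatter), the first change at this position that exceeds the usual scatter. The comparison with the saturated ring points the same way, with 3-chlorophenyl in place of cyclohexyl giving a 3.1-fold lower number from compound 1 to compound 3 (0.50 log units; beyond the scatter), even though cyclohexyl and 4-methoxyphenyl could not be told apart. Nothing measured here accounts for this difference.

The swap changes both the substituent and its location on the ring, so the effect of the chlorine cannot be separated from that of its location. 4-Chlorophenyl and 3-methoxyphenyl would separate the two, while an aminomethyl group on the ring would test a quite different kind of substituent.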